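From Ethyl to 4-Hydroxycyclohexyl on the Aromatic Nitrogen

The source may report more compounds than this note shows. Statements on the series, on what has been measured and on what is new or still open speak of the compounds shown alone.

In a functional assay on LNCaP cells (Homo sapiens) for cytotoxicity (on this read-out higher numbers stand for weaker inhibition and lower numbers for stronger inhibition), compound 3 `CCn1ncc2c(N3CC4CCC(C3)O4)nc(-c3ccc(NC(=O)NC)cc3)nc21` gives 70 nM, the highest number of the three measured, against compound 1 `CNC(=O)Nc1ccc(-c2nc(N3CC4CCC(C3)O4)c3cnn(C(C)C)c3n2)cc1` at 5 nM and compound 2 `CNC(=O)Nc1ccc(-c2nc(N3CC4CCC(C3)O4)c3cnn([C@H]4CC[C@@H](OC)CC4)c3n2)cc1` at 1 nM. Compound 4 `CNC(=O)Nc1ccc(-c2nc(N3CC4CCC(C3)O4)c3cnn([C@H]4CC[C@H](O)CC4)c3n2)cc1` carries 4-hydroxycyclohexyl in place of ethyl on an aromatic nitrogen. For the measured compounds named here, the closest precedent is compound 2, with 4-methoxycyclohexyl at that nitrogen: ethyl in its place gave a large step, a 70-fold higher number from compound 2 to compound 3 (1.85 log units; beyond the scatter). Isopropyl sits in between, with a 5.0-fold lower number from compound 1 to compound 2 (0.70 log units; beyond the scatter) and a 14-fold higher number from compound 1 to compound 3 (1.15 log units; beyond the scatter). Going by the values given here, no measured step compares 4-hydroxycyclohexyl with 4-methoxycyclohexyl, so the range stays wide. A large step to a lower number is expected, estimated as a 35-fold lower number from compound 3 to compound 4 (1.54 log units; beyond the scatter). For compound 4 the estimated value is 2 nM, with an expected range of 0.6 nM to 8 nM.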

Compound 4, half-maximal inhibitory concentration: 20 nM
Compound 4: middle estimate off by 10-fold (1.00 log units), on the low side; the measured number lies above the stated range.
By their numbers in this assay, from the lowest: compound 2; then compound 1; then compound 4; then compound 3.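

The result shows that what hangs on the cyclohexyl ring matters at this nitrogen: 4-hydroxycyclohexyl gives only a 3.5-fold lower number from compound 3 to compound 4 (0.54 log units; beyond the scatter), whereas the swap from 4-methoxycyclohexyl gives a 20-fold higher number from compound 2 to compound 4 (1.30 log units; beyond the scatter). The larger ring with its hydroxyl also does not match isopropyl, with a 4.0-fold higher number from compound 1 to compound 4 (0.60 log units; beyond the scatter), so the order at this position does not follow group size alone. Nothing available explains these differences.

Compound 2 and compound 4 are also drawn with different ring stereochemistry, so the effect of the methyl on oxygen stands unseparated from it. From the compounds shown here alone, how an amine or a carboxylic acid on that ring would behave remains open.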